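A few compounds are considered here, and "the series" means these few. Any claim that something is new, unique, unknown or untested is made for them only; others in the source may bear on it.

Compound 1 `Cc1cc(Cl)c(S(C)(=O)=O)cc1C(=O)N=C(N)N`, compound 2 `Cc1cc(C2CCCCC2)c(S(C)(=O)=O)cc1C(=O)N=C(N)N` and compound 3 `Cc1cc(OC2CCCC2)c(S(C)(=O)=O)cc1C(=O)N=C(N)N` share one core and differ only in the group on one aromatic carbon. In a functional assay for inhibition of sodium/hydrogen exchanger (Oryctolagus cuniculus) (a higher number here means a weaker inhibitor, a lower number a stronger inhibitor), compound 1 gives 25 nM, compound 2 gives 22 nM and compound 3 gives 27 nM. Compound 3 stands within the scatter of both neighbours: a 1.1-fold higher number from compound 1 to compound 3 (0.03 log units; within the scatter) and a 1.2-fold higher number from compound 2 to compound 3 (0.09 log units; within the scatter), as does a 1.1-fold lower number from compound 1 to compound 2 (0.06 log units; within the scatter). Compound 4 `Cc1cc(-n2ccnc2)c(S(C)(=O)=O)cc1C(=O)N=C(N)N` carries 1H-imidazol-1-yl in place of cyclopentyloxy on an aromatic carbon. Every step seen so far changes this same position, and none moves this assay beyond the scatter, so a step of no change at the digits printed from compound 3 to compound 4 (within the scatter) is expected, with no clear direction. Compound 4 is therefore estimated at 27 nM, with a range from 12 nM to 60 nM.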

Compound 4, half-maximal inhibitory concentration: 23 nM
For compound 4 the middle estimate is 1.2-fold (0.07 log units) above the measured one, within the range that was stated.
By their numbers in this assay, from the lowest: compounds 2, 4, 1 and 3 (each within the scatter of the next).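

For the compounds shown here, an aromatic ring with 2 hetero atoms now sits on this carbon, where the earlier compounds carried chloro, cyclohexyl or cyclopentyloxy, yet this assay does not separate it from them: there is a 1.2-fold lower number from compound 3 to compound 4 (0.07 log units; within the scatter) and a 1.0-fold higher number from compound 2 to compound 4 (0.02 log units; within the scatter) and also a 1.1-fold lower number from compound 1 to compound 4 (0.04 log units; within the scatter) for this change. All four groups on this carbon thus stand within the scatter of one another. Nothing available explains this result.

As far as these compounds go, whether an amine or a carboxylic acid on this carbon would also stay within the scatter remains open, as does whether replacing the methyl or the methylsulfonyl group would move the numbers in this assay at all.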